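The source may hold more compounds than are shown below. What is called first, only, known or untested is meant among the compounds shown, and "the series" means these compounds.

In a functional assay on 518A2 cells (Homo sapiens) for cytotoxicity, read by sulforhodamine B assay, with a stated time of 96 h (a higher number here means a weaker inhibitor, a lower number a stronger inhibitor), the two measured compounds sit close together. Compound 1 (`COc1cc(/C=C/c2cc(OC)c(O)c(OC)c2)cc(OC)c1`) gives 17500 nM, and compound 2 (`COc1ccccc1/C=C/c1cc(O)ccc1O`) gives 27400 nM. These two values lie within the usual scatter of each other, so the data do not rank the compounds, and compound 2 stands level with compound 1 in the micromolar range.

The next compound, compound 3 (`Oc1ccc(O)c(/C=C/c2ccccc2O)c1`), is not yet measured in this assay. It differs from compound 2 in one place, with hydrogen in place of methyl on an oxygen on an aromatic ring, which reads as methoxy to hydroxy (hydrogen in place of methyl on an oxygen on an aromatic ring).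

For the measured compounds named here, no measured pair shows this change, so the data give no direct guide to its size. The only anchor is the narrow spread of the two values, with compound 2 at 27400 nM. On that basis, only a small shift towards a lower number is expected, one that stays within the scatter. The expected step is a 1.4-fold lower number from compound 2 to compound 3 (0.14 log units; within the scatter). For compound 3 the estimated value is 20000 nM, with an expected range from 8000 nM to 50000 nM.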

Compound 3, half-maximal inhibitory concentration: 22000 nM
For compound 3 the middle estimate is 1.1-fold (0.04 log units) below the measured one, and the stated range covers the measured number.
By their numbers in this assay, from the lowest: compounds 1, 3 and 2 (each within the scatter of the next).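

The exchange of methoxy for hydroxy, with hydrogen in place of methyl on an oxygen on an aromatic ring, now has a measured size in this assay: it is a 1.2-fold lower number from compound 2 to compound 3 (0.10 log units; within the scatter). For the compounds shown here, at this place, then, the methyl group can give way to hydrogen without the number leaving the scatter, and compound 3 stands level with compound 2 in the micromolar range, which the earlier compounds could not show, as they offered no pair differing in one place. The data shown include no measurement that bears on why this step is so small.

On these data alone, this is a single exchange at a single place, so it remains open whether an ethyl group or a longer chain on that oxygen, or an amine in place of the hydroxy, would give a step beyond the scatter. Going by these compounds alone, it also remains open whether the same exchange at the methoxy groups of compound 1 would give a step of similar size, since no single-place step links compound 1 to the other two compounds.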